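Swapping a hydroxymethyl-tetrahydrofuran arm for a dimethylisoxazole

The source may hold more compounds than are shown below. What is called first, only, known or untested is meant among the compounds shown, and "the series" means these compounds.

For the measured compounds named here, compound 1 `Cc1cc(C)c(CN2CCc3c(Cl)cc([C@H](CO)[C@H]4CCOC4)c(Cl)c3C2=O)c(=O)[nH]1` is the only member of this small set that gives a plain number in an ADME assay on microsomes from liver (Homo sapiens) for metabolic stability, read by LC-MS, using NADPH, with stated times of 10 min and 45 min, tested at 1 uM; on this read-out lower numbers stand for slow clearance and higher numbers for fast clearance: compound 1 clears at 21.3 uL/min. Compound 2 `COc1cc(C)[nH]c(=O)c1CN1CCc2c(Cl)cc(C(OC)C3CCN(C(=O)CO)CC3)c(Cl)c2C1=O` has been run repeatedly, giving 12.6 uL/min; 25.6 uL/min (2 entries) in this assay, and the spread between the several entries of compound 2 in this assay, 12.6 uL/min; 25.6 uL/min (2 entries) is itself a reminder of how much repeat runs can differ. Compound 3 `COc1cc(C)[nH]c(=O)c1CN1CCc2c(Cl)cc([C@@H](O)C3COC3)c(Cl)c2C1=O` returns only a limit in this assay, < 7 uL/min, so no number is known for it; the presence of the limit of < 7 uL/min in this assay, at which 1 of the 3 values shown sits, marks the floor of what can be resolved. Compound 4 `Cc1cc(C)c(CN2CCc3c(Cl)cc(-c4c(C)noc4C)c(Cl)c3C2=O)c(=O)[nH]1` has not yet been measured. It differs from compound 1 by a group of 7 heavy atoms (5 carbon, 1 nitrogen, 1 oxygen; one five-membered aromatic ring with 2 hetero atoms) in place of a group of 8 heavy atoms (6 carbon, 2 oxygen; one five-membered non-aromatic ring with 1 hetero atom), on an aromatic carbon. Going by the values given here, no step between measured compounds is available to calibrate such a change. The step is estimated as a 1.2-fold higher number from compound 1 to compound 4 (0.09 log units; within the scatter), a mild rise that may not exceed the usual scatter. Compound 4 is therefore expected to show about 26 uL/min in this assay, within a range from 11 uL/min to 60 uL/min.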

Compound 4, intrinsic clearance in a liver preparation (reported as CLH), per the amount of preparation that the assay uses: 107 uL/min
For compound 4 the middle estimate is 4.1-fold (0.61 log units) below the measured one; the whole stated range lies below it.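

In this assay, for the compounds shown here, the exchange on this aromatic carbon gives a 5.0-fold higher number from compound 1 to compound 4 (0.70 log units; beyond the scatter), so this position does not tolerate every group alike, something the earlier compounds, with no step between them, could not show. With 3,5-dimethyl-1,2-oxazol-4-yl in place, the hydrogen-bond donor, the two defined stereocentres and the non-aromatic ring all leave together, and this single step cannot assign the rise to any one of them. The step is printed as beyond the scatter, although repeat runs can differ: the several entries of compound 2 in this assay, 12.6 uL/min; 25.6 uL/min (2 entries)

The compounds shown leave open how an amine or a carboxylic acid on this aromatic carbon would read. They also leave open whether 3,5-dimethyl-1,2-oxazol-4-yl would give a similar step on the methoxy-bearing compound 2 and compound 3.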